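The source may hold more compounds than are shown below. What is called first, only, known or untested is meant among the compounds shown, and "the series" means these compounds.

Compound 1 `C[C@H]1CC(Cl)=C([Si](C)(C)C)[C@@H](C2CCCCC2)O1`: 17000 nM
Compound 2 `C[Si](C)(C)C1=C(Cl)C[C@H](Cc2ccccc2)O[C@@H]1CCCCCCCCCC1C=C(Cl)CCO1`: 23000 nM
Compound 3 `C[C@@H]1O[C@H](C2CCCCC2)C([Si](C)(C)C)=C(Cl)[C@H]1C`: 19000 nM

In a functional assay on A2780 cells (Homo sapiens) for antiproliferative activity (on this read-out higher numbers stand for weaker inhibition of growth and lower numbers for stronger inhibition of growth), compound 1 gives 17000 nM. In the same this assay compound 2 gives 23000 nM and compound 3 gives 19000 nM. Compound 3 stands second highest of the three numbers, yet its gaps to compound 1 and to compound 2 are both within the scatter, so the three compounds cannot be told apart on these data. For the measured compounds named here, the only step between compounds that differ in one place is a 1.1-fold higher number from compound 1 to compound 3 (0.05 log units; within the scatter), a change that lies within the scatter.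

Compound 4 `C[C@@H]1O[C@H](CCC=C(Br)Br)C([Si](C)(C)C)=C(Cl)[C@H]1C` differs from compound 3 by 4,4-dibromobut-3-en-1-yl in place of cyclohexyl on a saturated ring carbon. Going by the values given here, no measured pair of compounds shares this exchange, so no step bears on it directly. Among the compounds with values here, the one measured step, a 1.1-fold higher number from compound 1 to compound 3 (0.05 log units; within the scatter), shows only that a small change elsewhere on the shared core left the number where it was, and all three measured compounds sit close together. Going by these compounds, on that basis a step beyond the scatter is not expected in this assay, in either direction, but the range must stay wide since the exchange is untested. Compound 4 is therefore expected to give 19000 nM in this assay, with a range from 7000 nM to 50000 nM. The expected step is no change at the digits printed from compound 3 to compound 4 (within the scatter).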

Compound 4, concentration for 50% growth inhibition: 16000 nM
Estimate against measurement, compound 4: 1.2-fold (0.07 log units) above, within the range that was stated.
By their numbers in this assay, from the lowest: compounds 4, 1, 3 and 2 (each within the scatter of the next).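

At this position, the saturated ring carbon next to the ring oxygen, this assay does not separate cyclohexyl from 4,4-dibromobut-3-en-1-yl: the step is a 1.2-fold lower number from compound 3 to compound 4 (0.07 log units; within the scatter). The earlier step concerned only a methyl in place of hydrogen on a different ring carbon, whereas this exchange replaces a six-membered carbon ring with an open chain that carries bromine and a double bond, so the two groups are quite different in kind, yet the read-out stays within the scatter. For this pair, then, the ring at this position is not needed to keep a number of this size, although the pair says nothing about why, and no measurement shown bears on a cause.

Going by these compounds, whether any group at this position can move the number beyond the scatter remains open, and an amine or a carboxylic acid at the end of a chain in place of 4,4-dibromobut-3-en-1-yl would test that. Also open, on these data alone, is whether the bromine atoms count for anything, which a plain butyl chain at the same carbon would address.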